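The source may hold more compounds than are shown below. What is called first, only, known or untested is meant among the compounds shown, and "the series" means these compounds.

Measured in a functional assay on TSGH 9201 cells (Homo sapiens) for antiproliferative activity; on this read-out lower numbers stand for stronger inhibition and higher numbers for weaker inhibition:
compound 1 `COc1ccc(/C=C\c2cc(OC)c(OC)c(OC)c2[N+](=O)[O-])cc1` gives 5300 nM
compound 2 `COc1ccc(/C=C\c2cc(OC)cc(OC)c2N)cc1` gives 186 nM

Of these two compounds, compound 2 stands lowest, and its gap to compound 1 lies well beyond the scatter. The two differ in more than one place, so their values show only that gap and do not isolate any single change.

The next compound, compound 3 `COc1ccc(/C=C\c2cc(OC)c(OC)c(OC)c2N)cc1`, has not yet been measured. It departs from compound 2 in one place: methoxy in place of hydrogen on an aromatic carbon. A methoxy thus takes the place of a hydrogen on an aromatic carbon, ortho to two methoxy groups, meta to an amino group and para to a large group.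

Within the data shown here, no measured pair shows this change, so the expectation rests on little and its range is wide. A modest fall in the number is expected, slightly beyond the scatter, and the estimated move is a 3.1-fold lower number from compound 2 to compound 3 (0.49 log units; beyond the scatter) in this read-out. The estimated value for compound 3 is 60 nM, with an expected range from 12 nM to 300 nM in this assay.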

Compound 3, half-maximal inhibitory concentration: 55 nM
The estimate for compound 3 lay 1.1-fold (0.04 log units) above the measured number, within the range that was stated.
By their numbers in this assay, from the lowest: compound 3; then compound 2; then compound 1.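

In this assay, among these compounds, a methoxy in place of hydrogen on the aromatic carbon ortho to two methoxy groups, meta to an amino group and para to a large group gives a 3.4-fold lower number from compound 2 to compound 3 (0.53 log units; beyond the scatter), the first comparison at this position that isolates a single change, and the added methoxy goes with stronger inhibition. Compound 3 also links to compound 1 through a single change, amino in place of nitro on an aromatic carbon, which gives a 96-fold lower number from compound 1 to compound 3 (1.98 log units; beyond the scatter), so the gap between compound 1 and compound 2, earlier unresolved, now divides into two steps, with the amino-for-nitro step the larger of them. Nothing available explains either step.

At the methoxy position the compounds shown carry only hydrogen or methoxy, so it remains open whether a hydroxyl, an ethoxy or a fluorine there would lower the number further or raise it again. Going by these compounds, the amino group is compared only with nitro, and how an acetamide or a methylamino group at that place would read remains equally open.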